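Exchanging the bromophenyl for a hydroxyphenyl on the shared core

The compounds below may be only part of what the source reports. "The series", "measured", "known", "first", "only" and "open" are said of these compounds alone.

Measured compounds and their values:
- compound 1, `COc1cc(/C=C2\CCC/C(=C\c3ccc(O)c(O)c3)C2=O)cc(OC)c1OC`: 2700 nM
- compound 2, `COc1cc(/C=C2\CCC/C(=C\c3ccccc3Br)C2=O)cc(OC)c1OC`: 2800 nM
- compound 3, `COc1ccccc1/C=C1\CCC/C(=C\c2cc(OC)c(OC)c(OC)c2)C1=O`: 1100 nM

These three compounds share one core and differ only in the aryl group on a double-bonded chain carbon bound to a double-bonded ring carbon. In a functional assay on LoVo cells (Homo sapiens) for antiproliferative activity, read by MTT assay, with a stated time of 72 h (on this read-out lower numbers stand for stronger inhibition and higher numbers for weaker inhibition), compound 2 gives the highest of the three numbers; compound 1 sits within the scatter of it, and compound 3 lies furthest, as the step of a 2.5-fold lower number from compound 2 to compound 3 (0.41 log units; beyond the scatter) shows.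

Compound 4, `COc1cc(/C=C2\CCC/C(=C\c3cccc(O)c3)C2=O)cc(OC)c1OC`, arises from compound 2 by the change (3-hydroxyphenyl in place of 2-bromophenyl on a double-bonded chain carbon bound to a double-bonded ring carbon). Among the measured compounds shown here, two measured steps bear on this. The step of a 1.0-fold higher number from compound 1 to compound 2 (0.02 log units; within the scatter) shows that a hydroxyl-bearing aryl and the bromophenyl gave numbers within the scatter of each other. The step of a 2.5-fold lower number from compound 2 to compound 3 (0.41 log units; beyond the scatter) shows that replacing the bromo by methoxy lowered the number modestly. For the measured compounds named here, no measured step places a single hydroxyl on this aryl, so the expectation for compound 4 leans on compound 1 and stays close to compound 2. The step of a 1.3-fold lower number from compound 2 to compound 4 (0.10 log units; within the scatter) is expected to stay within the scatter. Compound 4 is therefore estimated at 2200 nM in this assay, with a range from 900 nM to 5500 nM.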

Compound 4, half-maximal inhibitory concentration: 4800 nM
Beside the measured number, compound 4's estimate is 2.2-fold (0.34 log units) below it; low and high end bracket the measured number.
By their numbers in this assay, from the lowest: compound 3; then compounds 1, 2 and 4 (each within the scatter of the next).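

Swapping 2-bromophenyl for 3-hydroxyphenyl at this position stays within the scatter (a 1.7-fold higher number from compound 2 to compound 4 (0.23 log units; within the scatter)) in this assay, and so does taking one hydroxy off the 3,4-dihydroxyphenyl group (a 1.8-fold higher number from compound 1 to compound 4 (0.25 log units; within the scatter)). The 2-methoxyphenyl group now stands apart from a third aryl group (a 4.4-fold higher number from compound 3 to compound 4 (0.64 log units; beyond the scatter)), so among these four compounds only that group gives a number clearly separated from the others. Nothing measured here accounts for that separation.

A 2-hydroxyphenyl or a 3-methoxyphenyl group would help show whether the methoxy group itself or its place on the ring sets this compound apart. On these data alone, how an amine or a carboxylic acid on this aryl ring would change the number also remains open.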